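A few compounds are considered here, and "the series" means these few. Any claim that something is new, unique, unknown or untested is made for them only; others in the source may bear on it.

Measured so far in a functional assay on MV4-11 cells (Homo sapiens) for antiproliferative activity, read by luminescence, with a stated time of 72 h; a lower number here means a stronger inhibitor, a higher number a weaker inhibitor: compound 1 `COc1cc(O)c(C(=O)OCC2CCCCC2)c(/C=C/CN2C(=O)C=CC2=O)c1`, 1970 nM; compound 2 `COc1cc(O)c(C(=O)OC(C)C)c(/C=C/CN2C(=O)C=CC2=O)c1`, 1730 nM; compound 3 `C/C=C/C(=O)NC/C=C/c1cc(OCCc2ccc(F)cc2)cc(O)c1C(=O)OC(C)C`, > 10000 nM.

Within the data shown here, compound 2 gives the lowest of the two numbers in this assay, with compound 1 the nearest, and the one measured step, a 1.1-fold lower number from compound 1 to compound 2 (0.06 log units; within the scatter), lies within the scatter. For compound 3 the value in this assay is a limit of the assay, not a number (the limit of > 10000 nM in this assay, at which 1 of the 3 values shown sits). Compound 4 `C=CC(=O)NC/C=C/c1cc(OC)cc(O)c1C(=O)OC(C)C` differs from compound 2 in one place: a group of 5 heavy atoms (3 carbon, 1 nitrogen, 1 oxygen; no ring) in place of a group of 7 heavy atoms (4 carbon, 1 nitrogen, 2 oxygen; one five-membered non-aromatic ring with 1 hetero atom), on a saturated chain carbon bound to a double-bonded chain carbon. Among the measured compounds shown here, no measured step covers this change. Compound 3, which carries an open-chain amide and a different aryl ether, sits at that limit. On that basis compound 4 is expected to give a somewhat higher number than compound 2, a step of a 2.3-fold higher number from compound 2 to compound 4 (0.36 log units; beyond the scatter), with the estimate 4000 nM in a range from 1200 nM to 15000 nM.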

Compound 4, half-maximal inhibitory concentration: > 10000 nM
Compound 4: no number, only a limit; the forecaster's own chance of this, stated with the estimate: 25%; middle value at least 2.5-fold (0.39 log units) from the limit.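

In this assay, (vinylcarbonyl)amino in place of the group with the five-membered non-aromatic ring gives an at least 5.7-fold higher number from compound 2 to compound 4 (0.76 log units; beyond the scatter). This first measured step at this place, on a saturated chain carbon bound to a double-bonded chain carbon, lies beyond the scatter, whereas the earlier step, on an oxygen next to a carbonyl group, lies within it. Compound 4 gives a limit of the assay, not a number: the limit of > 10000 nM in this assay, at which 2 of the 4 values shown sit.

From the compounds shown here alone, what an amine or a propanoyl amide would give at this place remains open. Also open, going by these compounds, is whether the step holds with cyclohexylmethyl on the oxygen next to the carbonyl group.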